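Swapping Pyridinyl for Fluorophenyl on the Outer Aromatic Ring

The source may hold more compounds than are shown below. What is called first, only, known or untested is meant among the compounds shown, and "the series" means these compounds.

Compound 1 `CC[C@H](C)[C@H](N)CN(C(=O)[C@@H]1C[C@H]1c1ccc(F)cc1F)c1ccc(-c2ccccc2)cc1`: 1300 nM
Compound 2 `CC[C@H](C)[C@H](N)CN(C(=O)[C@@H]1C[C@H]1c1ccncc1)c1ccc(-c2ccccc2)cc1`: 1500 nM
Compound 3 `CC(C)C[C@H](N)CN(C(=O)[C@@H]1C[C@H]1c1ccccc1)c1ccc(-c2ccncc2)cc1`: 13000 nM

All three compounds share one core and were tested in a functional assay for agonist activity at G protein-coupled receptor 88 (Homo sapiens), read by HTRF and cAMP accumulation; a lower number here means that less compound is needed, a higher number that more compound is needed for the effect. Compound 3 gives the highest number of the three; both compound 2, the nearest, and compound 1, the furthest, sit well beyond the scatter below it.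

Compound 4 `CC(C)C[C@H](N)CN(C(=O)[C@@H]1C[C@H]1c1ccccc1)c1ccc(-c2cccc(F)c2)cc1` has not yet been measured. It differs from compound 3 in a single place: 3-fluorophenyl in place of pyridin-4-yl on an aromatic carbon.

Going by the values given here, only one measured step exists, a 1.2-fold higher number from compound 1 to compound 2 (0.06 log units; within the scatter), and it concerns the ring on a saturated ring carbon of the shared core, not the outer aromatic ring. Among the compounds with values here, it tells only that an exchange of an aryl group for pyridin-4-yl at that other place left the number essentially unchanged. Within the data shown here, no measured step addresses the outer aromatic position directly. What can be said is that compound 1 and compound 2, which carry a plain phenyl there, give lower numbers in this assay than compound 3 with its pyridin-4-yl, though they also differ from compound 3 elsewhere.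

On that basis a moderately lower number is expected for compound 4, a 3.7-fold lower number from compound 3 to compound 4 (0.57 log units; beyond the scatter), with wide uncertainty. The estimate for compound 4 is 3500 nM, ranging from 900 nM to 13000 nM.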

Compound 4, half-maximal effective concentration: 2100 nM
The estimate for compound 4 lay 1.7-fold (0.22 log units) above the measured number, within the range that was stated.
By their numbers in this assay, from the lowest: compounds 1, 2 and 4 (each within the scatter of the next); then compound 3.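

Going by these compounds alone, this is the first measured step at the outer aromatic ring, the one on an aromatic carbon para to a large group. In this assay there is a 6.2-fold lower number from compound 3 to compound 4 (0.79 log units; beyond the scatter), so the number does respond to a change at this place, whereas the exchange on a saturated ring carbon gave a 1.2-fold higher number from compound 1 to compound 2 (0.06 log units; within the scatter), which lies within the scatter. The step replaces pyridin-4-yl, a ring with one nitrogen and one hydrogen-bond acceptor, with 3-fluorophenyl, a ring of carbon only that carries a fluorine, so it removes the nitrogen and adds the fluorine in one move, and no measurement available here explains the lower number.

Which of those two alterations accounts for the step remains open, and a plain phenyl at this place on the core of compound 3 would help separate them. Going by these compounds, how a methoxy group, a nitrile or an amine on this ring would shift the number in this assay also remains unknown.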